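Arylidene cyclohexanone series: chlorine replaces methyl on one ring

The source may hold more compounds than are shown below. What is called first, only, known or untested is meant among the compounds shown, and "the series" means these compounds.

Three compounds share a core with two arylidene arms. In an assay on isolated protein for inhibition of Alpha glucosidase (Homo sapiens), with stated times of 5 min and 15 min, tested at 50 uM (on this read-out higher numbers stand for more inhibition at the one concentration tested (going by the name of the read-out) and lower numbers for less inhibition), compound 1 `O=C1/C(=C/c2ccccc2)CCC/C1=C\c1ccc(F)cc1` gives 34%, compound 2 `O=C1/C(=C/c2ccccc2)CCC/C1=C\c1cccc(Cl)c1Cl` gives 44%, and compound 3 `Cc1cccc(/C=C2\CCC/C(=C\c3ccccc3)C2=O)c1` gives 47.9%. Compound 3 stands at the highest of the three numbers, yet compound 2 lies within the scatter of it, while compound 1 lies beyond it: a number 13.9 percentage points higher from compound 1 to compound 3 (beyond the scatter).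

Compound 4 `O=C1/C(=C/c2ccccc2)CCC/C1=C\c1ccccc1Cl` has not yet been measured in this assay. It differs from compound 3 in one place: 2-chlorophenyl in place of 3-methylphenyl on a double-bonded chain carbon bound to a double-bonded ring carbon. Among the compounds with values here, the only measured step that bears on this arm is the one from compound 1 to compound 3, which was modest and beyond the scatter. Compound 2, whose arm carries chlorine too, shows a number close to that of compound 3. The author therefore expects no step beyond the scatter, leaning slightly downward, so that the estimated step is a number 5.9 percentage points lower from compound 3 to compound 4 (within the scatter). For compound 4 the estimate in this assay is 42%, ranging from 28% to 56%.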

Compound 4, a percentage reported as inhibition, at one concentration (the size of the read-out at that concentration, not a potency): 43%
Estimate against measurement, compound 4: 1 percentage points below; the range from low to high includes it.
By their numbers in this assay, from the lowest: compounds 1, 4, 2 and 3 (each within the scatter of the next, the first and the last beyond it).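

In this assay, 2-chlorophenyl in place of 3-methylphenyl on a double-bonded chain carbon bound to a double-bonded ring carbon gives a number 4.9 percentage points lower from compound 3 to compound 4 (within the scatter) and so does not separate these two arms. Hydrogen in place of chloro on an aromatic carbon gives a number 1 percentage points lower from compound 2 to compound 4 (within the scatter), so the second chloro of compound 2 shows no effect beyond the scatter on this read-out. Against the 4-fluorophenyl arm, the 2-chlorophenyl arm gives a number 9 percentage points higher from compound 1 to compound 4 (within the scatter), whereas the 3-methylphenyl arm gives a number 13.9 percentage points higher from compound 1 to compound 3 (beyond the scatter), so only the latter step clears the scatter. Nothing measured here accounts for these steps. Going by these compounds, whether an amine or a carboxylic acid on this arm would shift the inhibition beyond the scatter remains open.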